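Propoxy to phenoxy on the shared core

The compounds below may be only part of what the source reports. "The series", "measured", "known", "first", "only" and "open" are said of these compounds alone.

Among the compounds with values here, in a functional assay on PC-3 cells (Homo sapiens) for inhibition, read by sulforhodamine B assay, with a stated time of 48 h, tested at 50 uM (a higher number here means more inhibition of growth at the concentration tested, a lower number less inhibition of growth), compound 1 (`CCCOc1ccc([C@@H]2CC(=O)c3cc(CC=C(C)C)c(OC)cc3O2)cc1`) gives 54% and stands highest of the two numbers so far. Compound 2 (`COc1ccc([C@@H]2C/C(=N/OCc3cn(-c4cc(OC)c(OC)c(OC)c4)nn3)c3cc(CC=C(C)C)c(OC)cc3O2)cc1`) gives 36% and lies lower, beyond the scatter. Compound 3 (`COc1cc2c(cc1CC=C(C)C)C(=O)C[C@@H](c1ccc(Oc3ccccc3)cc1)O2`) carries phenyl in place of propyl on an oxygen on an aromatic ring. Within the data shown here, no measured pair shows this change, so the step expected in this assay is none beyond the scatter, estimated as a number 4 percentage points lower from compound 1 to compound 3 (within the scatter) for now. For compound 3 the expected value is 50% with an estimated range from 30% to 70% in this series.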

Compound 3, percent growth inhibition at one concentration: 53%
Compound 3: middle estimate off by 3 percentage points, on the low side; the measured number falls inside the stated range.
By their numbers in this assay, from the lowest: compound 2; then compounds 3 and 1 (each within the scatter of the next).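

Within the data shown here, this is the only one-place comparison so far: in this assay the step is a number 1 percentage points lower from compound 1 to compound 3 (within the scatter). On this oxygen on an aromatic ring, then, an open propyl chain and a phenyl ring cannot be told apart by growth inhibition at the single concentration tested. Nothing available bears on why the two read alike.

Open, from the compounds shown here alone, is whether a longer chain such as octyl, or a carboxylic acid or an amine carried on this oxygen, would separate from propyl and phenyl. Substituted phenyl rings at this place also remain open.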